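Trifluoromethoxy to trifluoroethoxy on a hydrazide core

This account rests on a few compounds, and the source may have more. Where it says the series, first, only, none or still open, it means among the compounds named here.

Measured compounds:
Compound 1 `O=C(NNC(=O)C1CC1c1ccc(OC(F)(F)F)cc1)c1ccncc1`: "not determined" (no result reported)
Compound 2 `O=C(NNc1nncc2ccccc12)C1CC1c1ccc(OC(F)(F)F)cc1`: 29000 nM
Compound 3 `CC(C)=CCC/C(C)=C/COc1ccc(C2CC2C(=O)NNc2nncc3ccccc23)cc1`: 25000 nM

Three compounds have been examined in a functional assay on SK-MEL cells (Homo sapiens) for inhibition, read by MTT assay, with a stated time of 72 h; a lower number here means a stronger inhibitor, a higher number a weaker inhibitor. For compound 1 the outcome is "not determined" (no result reported), so compound 1 has no place on the scale yet. Compound 2 gives 29000 nM in this assay, a weak inhibition. Compound 3 gives 25000 nM in this assay, and the step of a 1.2-fold lower number from compound 2 to compound 3 (0.06 log units; within the scatter) shows that exchanging the group on the aromatic oxygen in that pair made no difference worth noting.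

Compound 4 `O=C(NNC(=O)C1CC1c1ccc(OCC(F)(F)F)cc1)c1ccncc1` is the unmeasured compound. It differs from compound 1 in one place: 2,2,2-trifluoroethyl in place of trifluoromethyl on an oxygen on an aromatic ring. Within the data shown here, no measured pair shares exactly this exchange. Among the measured compounds shown here, the only comparison available, from compound 2 to compound 3, concerns a different core and a different incoming group, yet it also alters the group on the same aromatic oxygen, and that step stayed within the scatter. Both measured values sit in the weak range, and nothing indicates that the core of compound 1 behaves otherwise. The expectation for compound 4 in this assay is therefore weak inhibition of a similar order, with wide uncertainty since compound 1 itself is unmeasured. Compound 4 is estimated at 30000 nM, with a range from 6000 nM to 150000 nM.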

Compound 4, half-maximal inhibitory concentration: 81000 nM
Compound 4: the middle estimate sits 2.7-fold (0.43 log units) below what was measured; the measured number falls inside the stated range.
By their numbers in this assay, from the lowest: compounds 3 and 2 (each within the scatter of the next); then compound 4.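

No step can be read from compound 1 to compound 4: compound 1 has no number on this scale, so the result for compound 4 stands alone. The compounds shown leave open what trifluoromethoxy to 2,2,2-trifluoroethoxy does on this shared core. No evidence is at hand that bears on the value of compound 4.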